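A few compounds are considered here, and "the series" means these few. Any claim that something is new, unique, unknown or untested is made for them only; others in the source may bear on it.

Compound 1 `O=C(O)c1ccc2nc(CN3CCC[C@H](O[C@H](CO)c4cc(Cl)cc(Cl)c4)[C@@H]3c3ccccc3)[nH]c2c1` is one of three compounds whose activity was measured in an assay on isolated protein for activation of cGMP-dependent protein kinase 1 (Homo sapiens), read by ADP-Glo, with stated times of 30 min and 2 h, in the presence of a further agent that is not named here; on this read-out higher numbers stand for an effect only at larger amounts of compound and lower numbers for an effect already at smaller amounts. In this assay compound 1 gives 380 nM, the lowest of the three numbers and so the one that shows an effect at the smallest amount of compound. Compound 2 `Cc1cc(C(=O)O)ccc1CN1CCC[C@H](O[C@H](CO)c2ccnc(Cl)c2)[C@@H]1c1ccccc1` gives 50000 nM in this assay, and compound 3 `Cc1cc(C(=O)O)ccc1CN1CC[C@H](OC(CO)c2cc(Cl)cc(Cl)c2)[C@@H]1c1ccccc1` gives 133000 nM, both far beyond the usual scatter away from compound 1; each of them differs from compound 1 in more than one place, so no single change can be read from them.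

Compound 4 `O=C(O)c1ccc(CN2CCC[C@H](O[C@H](CO)c3cc(Cl)cc(Cl)c3)[C@@H]2c2ccccc2)c(C2CC2)c1` has not yet been measured. It differs from compound 1 in one place: a group of 12 heavy atoms (10 carbon, 2 oxygen; one three-membered non-aromatic ring of carbon only, one six-membered aromatic ring of carbon only) in place of a group of 12 heavy atoms (8 carbon, 2 nitrogen, 2 oxygen; one five-membered aromatic ring with 2 hetero atoms, one six-membered aromatic ring of carbon only), on a saturated chain carbon bound to an amine nitrogen in a ring. Within the data shown here, no measured pair shows this change on its own, and the three measured compounds give no direct guide to it. A shift toward a higher number, moderate in size, is expected for the step of a 3.9-fold higher number from compound 1 to compound 4 (0.60 log units; beyond the scatter) in this assay. For compound 4 the expected value in this assay is 1500 nM, with a range from 300 nM to 8000 nM.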

Compound 4, half-maximal effective concentration: 1800 nM
The estimate for compound 4 lay 1.2-fold (0.08 log units) below the measured number, within the range that was stated.
By their numbers in this assay, from the lowest: compound 1; then compound 4; then compound 2; then compound 3.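

Among these compounds, this is the first comparison in this assay that changes one place only. On a saturated chain carbon bound to an amine nitrogen in a ring, a group with a three-membered non-aromatic ring and a six-membered aromatic ring of carbon only replaces one with a five-membered aromatic ring with 2 hetero atoms, and this gives a 4.7-fold higher number from compound 1 to compound 4 (0.68 log units; beyond the scatter) in a modest step. Activity at this place therefore falls but is not lost when the entering group has 1 hydrogen-bond donor and 1 hydrogen-bond acceptor in place of 2 of each, and nothing measured here gives a reason for the shift.

The compounds shown cannot separate the part played by the three-membered ring from the part played by the lost five-membered ring. As far as these compounds go, whether a methoxy group in place of the three-membered ring would bring the number closer to that of compound 1 remains open.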